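Replacing a Hydroxycyclobutylmethyl Amine with a Carbamoyl Cyclobutyl Amine

The source may report more compounds than this note shows. Statements on the series, on what has been measured and on what is new or still open speak of the compounds shown alone.

Measured compounds: compound 1 `N#Cc1cnc(NCc2cnccc2C(F)(F)F)cc1NC[C@H]1C[C@H](O)C1`, > 10000 nM; compound 2 `N#Cc1cnc(NCc2ccccc2C(F)(F)F)cc1N[C@H]1CC[C@@H](C(N)=O)CC1`, 640 nM; compound 3 `CC1(C)C[C@H](Nc2cc(NCc3cnccc3C(F)(F)F)ncc2C#N)CC(C)(C)[C@@H]1O`, 700 nM.

In an assay on isolated protein for inhibition of protein kinase C delta type (Homo sapiens), read by TR-FRET, with a stated time of 2 h (on this read-out lower numbers stand for stronger inhibition and higher numbers for weaker inhibition), compound 1 reaches only a limit, > 10000 nM, the limit described by the limit of > 10000 nM in this assay, at which 1 of the 3 values shown sits. Compound 2 gives 640 nM in this assay, and compound 3 gives 700 nM. Compound 4 `CC1(C)[C@@H](Nc2cc(NCc3cnccc3C(F)(F)F)ncc2C#N)C[C@@H]1C(N)=O` differs from compound 1 by 3-carbamoyl-2,2-dimethylcyclobutyl in place of (3-hydroxycyclobutyl)methyl on a nitrogen on an aromatic ring. Since compound 1 sits at the limit, the direction of the step can only be toward stronger inhibition or no change. Compound 4 is expected to land near compound 2, whose value is 640 nM, so the expected step is an at least 12-fold lower number from compound 1 to compound 4 (1.09 log units; beyond the scatter). The estimate for compound 4 is 800 nM, within a range from 150 nM to 5000 nM.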

Compound 4, half-maximal inhibitory concentration: > 10000 nM
Compound 4: no number, only a limit (the forecaster's own chance of this, stated with the estimate: 20%); middle value at least 12-fold (1.09 log units) from the limit.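

In this assay compound 1 and compound 4 each give only a limit, so no step can be read between them: the limit of > 10000 nM in this assay, at which 2 of the 4 values shown sit. The compounds shown leave open whether 3-carbamoyl-2,2-dimethylcyclobutyl and (3-hydroxycyclobutyl)methyl differ at all on this read-out.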